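The compounds below may be only part of what the source reports. "The series", "measured", "known", "first", "only" and "open" are said of these compounds alone.

Compound 3 `CC(=O)Nc1cccc(-c2cnc(Nc3ccc(F)cc3)o2)c1` stands lowest of the two numbers in a physicochemical assay for solubility, using the shake flask method, measured as kinetic solubility, at pH 7.4 (on this read-out lower numbers stand for lower solubility and higher numbers for higher solubility), where compound 3 gives 5000 nM. Compound 2 `NCc1cccc(-c2cnc(Nc3ccc(F)cc3)o2)c1` is its nearest neighbour: in this assay compound 2 gives 50800 nM, and the step of a 10-fold lower number from compound 2 to compound 3 (1.01 log units; beyond the scatter) is large. Compound 1 `COC(=O)c1cccc(-c2cnc(Nc3ccc(F)cc3)o2)c1` gives only a limit in this assay, < 1000 nM. The change to compound 4 `Nc1cccc(-c2cnc(Nc3ccc(F)cc3)o2)c1` is hydrogen in place of acetyl on a nitrogen on an aromatic ring; read one bond further out, it is acetamido to amino. For the measured compounds named here, no measured step matches this change exactly; the nearest are an at least 5.0-fold higher number from compound 1 to compound 3 (0.69 log units; beyond the scatter) and a 10-fold lower number from compound 2 to compound 3 (1.01 log units; beyond the scatter), both changes of the group on an aromatic carbon and both beyond the scatter. Compound 4 is therefore expected to show a modest rise, a 2.4-fold higher number from compound 3 to compound 4 (0.38 log units; beyond the scatter). The estimate for compound 4 is 12000 nM, with a range from 3000 nM to 50000 nM.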

Compound 4, solubility: 15200 nM
Compound 4: middle estimate off by 1.3-fold (0.10 log units), on the low side, and the stated range covers the measured number.
By their numbers in this assay, from the lowest: compound 3; then compound 4; then compound 2. At a limit, below all of these: compound 1.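

In this assay taking the acetyl off the nitrogen gives a 3.0-fold higher number from compound 3 to compound 4 (0.48 log units; beyond the scatter) while shortening aminomethyl to amino gives a 3.3-fold lower number from compound 2 to compound 4 (0.52 log units; beyond the scatter) so the plain amino group lands between acetamido and aminomethyl. Amino in place of methoxycarbonyl gives an at least 15-fold higher number from compound 1 to compound 4 (1.18 log units; beyond the scatter) but compound 1 is held only at a limit: the limit of < 1000 nM in this assay, at which 1 of the 4 values shown sits.

The compounds shown leave open how a longer chain such as aminoethyl, or a carboxylic acid, would read on the same aromatic carbon. They also leave open whether a methyl group on the nitrogen of compound 4 would keep its number.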